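This account rests on a few compounds, and the source may have more. Where it says the series, first, only, none or still open, it means among the compounds named here.

Measured so far:
compound 1 `CCCC(=O)OCSc1ccccc1C(=O)NCC(N)=O` — in an ADME assay on CEM-SS cells (Homo sapiens) for cytotoxicity, read by XTT assay, with a stated time of 6 days (on this read-out higher numbers stand for lower toxicity in this test and lower numbers for higher toxicity in this test), compound 1 gives > 100 uM, which is a limit of the assay and not a number.
compound 2 `CCCC(=O)OCSc1ccccc1C(=O)N[C@@H]1CCC[C@@H]1C(N)=O` — in this assay compound 2 gives 90 uM.

Among the measured compounds shown here, compound 2 thus holds the only number in the set; the remaining value is a limit (the limit of > 100 uM in this assay, at which 1 of the 2 values shown sits). For the measured compounds named here, the one measured step, an at least 1.1-fold lower number from compound 1 to compound 2 (0.04 log units; that floor lies within the scatter), lies within the scatter and shows no change worth reading.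

Compound 3 `CCCC(=O)OCSc1ccccc1C(=O)NCC(=O)NC(C)(C)C` differs from compound 2 by ((tert-butyl)carbamoyl)methyl in place of 2-carbamoylcyclopentyl on an amide-type nitrogen. Going by the values given here, the only step that bears on this position is the one from compound 1 to compound 2, which sat within the scatter, so no change beyond the scatter is expected here either. For compound 3 the expected step is a 1.1-fold higher number from compound 2 to compound 3 (0.05 log units; within the scatter), which is estimated as no movement beyond the scatter. Compound 3 is therefore estimated at 100 uM, with a range from 50 uM to 200 uM, and a limit rather than a number remains plausible.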

Compound 3, half-maximal toxic concentration: 46.8 uM
Compound 3: the middle estimate sits 2.1-fold (0.33 log units) above what was measured; measured number outside the range, below it.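

In this assay, among the compounds shown here, tert-butyl in place of hydrogen on an amide-type nitrogen produces the first step that clears the scatter: an at least 2.1-fold lower number from compound 1 to compound 3 (0.32 log units; beyond the scatter). Compound 1 stands at a limit and not a number, so this step is only a floor: the limit of > 100 uM in this assay, at which 1 of the 3 values shown sits. The exchange of 2-carbamoylcyclopentyl for ((tert-butyl)carbamoyl)methyl, which removes the ring and keeps the same count of heavy atoms, gives no change worth reading: a 1.9-fold lower number from compound 2 to compound 3 (0.28 log units; within the scatter).

Going by these compounds, the true size of the tert-butyl step remains open, as does whether it depends on tert-butyl itself or on any group replacing the amide hydrogen. A methyl or a longer chain on that nitrogen, or a carboxylic acid in place of the carbamoyl group, would help separate these readings.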